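The source may hold more compounds than are shown below. What is called first, only, known or untested is meant among the compounds shown, and "the series" means these compounds.

In an assay on HL-60 cells for inhibition of E-selectin (Homo sapiens), tested at 50 mM (a higher number here means more inhibition at the concentration tested (going by the name of the read-out), a lower number less inhibition), compound 1 `O=C(O)CCCNC(=O)[C@]1(O)C[C@@H](O)[C@@H](O)[C@H](O)C1` gives 40%, compound 2 `O=C(O)CCCCCNC(=O)[C@]1(O)C[C@@H](O)[C@@H](O)[C@H](O)C1` gives 31% and compound 3 `O=C(O)CC[C@H](NC(=O)[C@]1(O)C[C@@H](O)[C@@H](O)[C@H](O)C1)C(=O)O` gives 43%. Compound 3 holds the highest of the three numbers; its gap to compound 1 is within the scatter, while its gap to compound 2 lies beyond it. Compound 4 `CCC(C)[C@H](NC(=O)[C@]1(O)C[C@@H](O)[C@@H](O)[C@H](O)C1)C(=O)O` differs from compound 3 by sec-butyl in place of 2-carboxyethyl on a saturated chain carbon bound to an amide-type nitrogen and a carbonyl carbon. Among the compounds with values here, two measured steps bear on this part of the series: a number 9 percentage points lower from compound 1 to compound 2 (within the scatter) and a number 3 percentage points higher from compound 1 to compound 3 (within the scatter), both within the scatter. The step to compound 4 removes what the carboxy-in-place-of-hydrogen step had added and then some, so the expected step of a number 6 percentage points lower from compound 3 to compound 4 (within the scatter) is small and, if anything, downward. Compound 4 is therefore estimated at 37%, with a range from 24% to 50%.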

Compound 4, a percentage reported as inhibition, at one concentration (the size of the read-out at that concentration, not a potency): 44%
Compound 4: middle estimate off by 7 percentage points, on the low side; the measured number falls inside the stated range.
By their numbers in this assay, from the lowest: compounds 2, 1, 3 and 4 (each within the scatter of the next, the first and the last beyond it).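

In this assay, sec-butyl in place of 2-carboxyethyl on a saturated chain carbon bound to an amide-type nitrogen and a carbonyl carbon gives a number 1 percentage points higher from compound 3 to compound 4 (within the scatter). At this position, then, an all-carbon group without hydrogen-bond donors or acceptors stands within the scatter of a group ending in a carboxylic acid, a replacement the steps among compounds 1, 2 and 3 did not test. No evidence is available to explain this result.

Open, from the compounds shown here alone, is whether an amine or a benzyl group at this carbon would stay within the scatter of compound 4. Also open, going by these compounds, is what an ester or amide in place of the remaining carboxylic acid on this carbon would give.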